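A few compounds are considered here, and "the series" means these few. Any claim that something is new, unique, unknown or untested is made for them only; others in the source may bear on it.

Three compounds have so far been measured in a functional assay on the whole organism (blood) with Rattus norvegicus as the target, with stated times of 24 h and 1 h, at a dose of 1 mg/kg by the intraperitoneal route; on this read-out higher numbers stand for a stronger effect at the one dose given and lower numbers for a weaker effect:

Compound 1 `O=C(NC[C@@H]1C[C@@H]2C=C[C@@H]1C2)NS(=O)(=O)N1CCC(CCNC(=O)c2nc3ccccc3s2)CC1`: 14%
Compound 2 `O=C(NC[C@@H]1C[C@@H]2C=C[C@@H]1C2)NS(=O)(=O)N1CCC(CCNC(=O)c2cccc3cccnc23)CC1`: 32%
Compound 3 `O=C(NC[C@@H]1C[C@@H]2C=C[C@@H]1C2)NS(=O)(=O)N1CCC(CCNC(=O)c2cc(Cl)cc3cccnc23)CC1`: 16%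

Compound 3 stands second highest of the three numbers. Its nearest neighbour is compound 1, and the two lie within the scatter of each other, as the step of a number 2 percentage points higher from compound 1 to compound 3 (within the scatter) shows. Its furthest neighbour is compound 2, and the step of a number 16 percentage points lower from compound 2 to compound 3 (beyond the scatter) lies beyond the scatter.

Compound 4 `Cn1cc(C(=O)NCCC2CCN(S(=O)(=O)NC(=O)NC[C@@H]3C[C@@H]4C=C[C@@H]3C4)CC2)c(=O)n(C)c1=O` has not been measured. It differs from compound 3 at the same carbonyl carbon that the measured steps touch: a group of 10 heavy atoms (6 carbon, 2 nitrogen, 2 oxygen; one six-membered aromatic ring with 2 hetero atoms) in place of a group of 11 heavy atoms (9 carbon, 1 nitrogen, 1 chlorine; one six-membered aromatic ring of carbon only, one six-membered aromatic ring with 1 hetero atom), on a carbonyl carbon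

The measured steps that bear on this position are a number 18 percentage points higher from compound 1 to compound 2 (beyond the scatter) and a number 16 percentage points lower from compound 2 to compound 3 (beyond the scatter), both modest, and neither exchanges the group for one of the kind that enters in compound 4. Among the compounds with values here, the three measured numbers span a narrow band, so no large step is foreseen, but the direction cannot be told from what is known. The step to compound 4 is therefore expected to be a number 2 percentage points higher from compound 3 to compound 4 (within the scatter), which is not beyond the scatter. For compound 4 the estimate in this assay is 18%, with a range from 5% to 35%.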

Compound 4, a percentage reported as activity, at one dose (the size of the read-out at that dose, not a potency): 12%
Beside the measured number, compound 4's estimate is 6 percentage points above it; low and high end bracket the measured number.
By their numbers in this assay, from the lowest: compounds 4, 1 and 3 (each within the scatter of the next); then compound 2.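

Within the data shown here, compound 4 brings the first group on this carbonyl carbon with a single aromatic ring, one with 2 hetero atoms and 2 double bonds outside aromatic rings, yet in this assay the exchange gives a number 4 percentage points lower from compound 3 to compound 4 (within the scatter) and a number 2 percentage points lower from compound 1 to compound 4 (within the scatter). The same group set against the unsubstituted quinolin-8-yl gives a number 20 percentage points lower from compound 2 to compound 4 (beyond the scatter), so compounds 1, 3 and 4 now form one group within the scatter of one another despite their different groups, and compound 2 alone stands clear of all three. Nothing measured alongside these numbers accounts for why quinolin-8-yl stands apart from the other groups at this position.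

The compounds shown leave open whether the step up in compound 2 belongs to quinolin-8-yl itself, or whether a plain phenyl, a pyridin-3-yl or a naphthalen-1-yl on the same carbonyl carbon would stand with it or with the other three. They also leave open whether a fluoro or a methoxy in place of the chloro of compound 3 would give the same step down from compound 2, and whether these groups would separate at any other dose.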